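Trimethoxyphenyl replacement for phenyl in the aminoquinoline series

This account rests on a few compounds, and the source may have more. Where it says the series, first, only, none or still open, it means among the compounds named here.

Compound 1 `CSc1nc(NCCCCNc2ccnc3cc(Cl)ccc23)c(C#N)c(-c2ccccc2)n1` gives 4400 nM in an ADME assay on L1210 cells (Mus musculus) for inhibition, read by cell counting; a lower number here means a stronger inhibitor, a higher number a weaker inhibitor. Among the two numbers available it is the highest; its nearest neighbour is compound 3 `CSc1nc(NCCCCNc2ccnc3cc(Cl)ccc23)c(C#N)c(-c2cccc([N+](=O)[O-])c2)n1`, which gives 2100 nM, and the step of a 2.1-fold lower number from compound 1 to compound 3 (0.32 log units; beyond the scatter) is a modest one, beyond the scatter. Compound 2 `CSc1nc(-c2ccccc2)c(C#N)c(N2CCN(c3ccnc4cc(Cl)ccc34)CC2)n1` gives > 250000 nM, which is a limit of the assay and not a number; it sits at the limit of > 250000 nM in this assay, at which 1 of the 3 values shown sits, and carries no information on the size of any step.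

Compound 4 `COc1cc(-c2nc(SC)nc(NCCCCNc3ccnc4cc(Cl)ccc34)c2C#N)cc(OC)c1OC` differs from compound 1 in one place: 3,4,5-trimethoxyphenyl in place of phenyl on an aromatic carbon. Going by the values given here, the only measured step on the same aromatic ring is the one from compound 1 to compound 3, a nitro in place of hydrogen on an aromatic carbon, which moved the number modestly downward. Among the compounds with values here, three methoxy groups enter here instead, and no measured pair shows what that does; the closest evidence is that a substituent on this ring is tolerated with a modest gain.

Compound 4 is therefore expected to stay close to compound 1, with a small step of a 1.5-fold lower number from compound 1 to compound 4 (0.17 log units; within the scatter) that may fall within the scatter. The estimate for compound 4 is 3000 nM, with a range from 900 nM to 10000 nM.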

Compound 4, half-maximal inhibitory concentration: 3800 nM
The estimate for compound 4 lay 1.3-fold (0.10 log units) below the measured number, and the stated range covers the measured number.
By their numbers in this assay, from the lowest: compounds 3, 4 and 1 (each within the scatter of the next, the first and the last beyond it). At a limit, above all of these: compound 2.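

The step (a 1.2-fold lower number from compound 1 to compound 4 (0.06 log units; within the scatter)) shows that, in this assay, this position takes 3,4,5-trimethoxyphenyl in place of phenyl without a change that can be told from the scatter, so growing the group from 6 to 12 heavy atoms and adding 3 hydrogen-bond acceptors leaves the number where it was. The new group also cannot be separated from 3-nitrophenyl (a 1.8-fold higher number from compound 3 to compound 4 (0.26 log units; within the scatter)), although 3-nitrophenyl and phenyl do stand apart (a 2.1-fold lower number from compound 1 to compound 3 (0.32 log units; beyond the scatter)), so compound 4 sits within the scatter of both and the series gives no simple order of substituents on this ring. No measurement in hand bears on why these aryl groups read so alike.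

Going by these compounds, whether an amine or a carboxylic acid on this ring, or a single methoxy group in place of the three, would move the number beyond the scatter remains open. Also open, on these data alone, is whether a longer chain in place of the present linking chain would alter the tolerance seen at this position.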